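Compound 3 against the 2-chlorophenyl compound

A few compounds are considered here, and "the series" means these few. Any claim that something is new, unique, unknown or untested is made for them only; others in the source may bear on it.

Measured in a physicochemical assay for lipophilicity, read by HPLC, at pH 7.5; on this read-out lower numbers stand for lower lipophilicity and higher numbers for higher lipophilicity:
compound 1 `CC[C@@H](Nc1c(C#N)c(-c2ccc(-c3ccncc3C)cc2)nc2cnccc12)C(N)=O`: 2
compound 2 `CC[C@@H](Nc1c(C#N)c(-c2ccc(-c3ccccc3Cl)cc2)nc2cnccc12)C(N)=O`: 2.9

Of the two measured compounds, compound 2 has the higher number, with 2.9 in this assay. The next compound, compound 3 `CC[C@@H](Nc1c(C#N)c(-c2ccc(-c3cccc(OC)c3)cc2)nc2cnccc12)C(N)=O`, carries 3-methoxyphenyl in place of 2-chlorophenyl on an aromatic carbon of a six-membered aromatic ring of carbon only, para to a large group (3-methoxyphenyl in place of 2-chlorophenyl on an aromatic carbon).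

Going by the values given here, the one measured step at this place is a number 0.90 log units higher from compound 1 to compound 2 (beyond the scatter), which is modest and beyond the scatter. Among the compounds with values here, it bears on the change only in part, since it shares 2-chlorophenyl but no measured compound carries 3-methoxyphenyl. With compound 1 at 2 as the only lower reference, a position much nearer compound 2 than compound 1 is expected.

The expected change is small and downward, not clearing the scatter: a number 0.20 log units lower from compound 2 to compound 3 (within the scatter). In this assay the estimate for compound 3 is 2.7, with an expected range from 2.3 to 3.1.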

Compound 3, distribution coefficient: 2.7
For compound 3 middle estimate and measured number coincide at the digits printed, within the range that was stated.
By their numbers in this assay, from the lowest: compound 1; then compounds 3 and 2 (each within the scatter of the next).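

In this assay, the exchange of 2-chlorophenyl for 3-methoxyphenyl on this aromatic carbon gives a number 0.20 log units lower from compound 2 to compound 3 (within the scatter), so compound 2 and compound 3 cannot be told apart here, although the entering group carries 1 hydrogen-bond acceptor and the leaving group 0. Against 3-methylpyridin-4-yl at the same place, the record now shows a number 0.70 log units higher from compound 1 to compound 3 (beyond the scatter), which means that compound 1 stands apart from two compounds with different substituted phenyl groups, not from compound 2 alone. No accompanying data explain either step.

Open, on these data alone, is how far this agreement extends at this position: an unsubstituted phenyl would give a common reference for the chlorine and the methoxy group, and would show whether each one shifts the read-out at all or whether the two compounds merely happen to coincide. Equally open, as far as these compounds go, is whether a carboxylic acid, an amine or a longer chain on this aromatic carbon would stay close to compound 2 and compound 3 or fall nearer to compound 1.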